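Replacing 3-hydroxyphenyl with 2-bromophenyl

The source may report more compounds than this note shows. Statements on the series, on what has been measured and on what is new or still open speak of the compounds shown alone.

In a functional assay on Lewis lung carcinoma cells for cytotoxicity against Lewis lung carcinoma cell line (Mus musculus), read by MTT assay, with a stated time of 72 h (a lower number here means a stronger inhibitor, a higher number a weaker inhibitor), compound 1 (`O=C1/C(=C/c2cccc(O)c2)COC/C1=C\c1ccccc1F`) gives 13800 nM. Compound 3 (`COc1ccc(OC)c(/C=C2\COC/C(=C\c3ccccc3F)C2=O)c1`) gives 15100 nM, within the usual scatter of compound 1. Compound 2 (`COc1cc(/C=C2\COC/C(=C\c3ccccc3F)C2=O)cc(OC)c1OC`) gives 6100 nM, a clearly lower number than either, so compound 1 shares the high end of this small set with compound 3.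

Compound 4 (`O=C1/C(=C/c2ccccc2F)COC/C1=C\c1ccccc1Br`) has not been measured. It carries 2-bromophenyl in place of 3-hydroxyphenyl on a double-bonded chain carbon bound to a double-bonded ring carbon. Among the compounds with values here, no measured pair isolates this change. The measured values stay fairly close, from compound 2 at 6100 nM to compound 3 at 15100 nM, so only a small shift is expected. The expected 1.4-fold lower number from compound 1 to compound 4 (0.14 log units; within the scatter) stays within the scatter, with no firm direction. Compound 4 is estimated at 10000 nM, with an expected range of 4000 nM to 25000 nM.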

Compound 4, half-maximal inhibitory concentration: 13300 nM
Beside the measured number, compound 4's estimate is 1.3-fold (0.12 log units) below it; the range from low to high includes it.
By their numbers in this assay, from the lowest: compound 2; then compounds 4, 1 and 3 (each within the scatter of the next).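

In this assay, within the data shown here, this swap gives a 1.0-fold lower number from compound 1 to compound 4 (0.02 log units; within the scatter) and so leaves the number unchanged within the scatter, the first direct reading at this position. Here 3-hydroxyphenyl counts a hydrogen-bond donor and acceptor while 2-bromophenyl counts neither, yet this difference comes with no readable shift. No measurement here offers a reason for this result. As far as these compounds go, whether a different kind of group at this place, such as an amine or a carboxylic acid, would move the number stays open. The effect of a longer chain there is also unknown.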